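Swapping an acid for a benzyl ester in a nucleoside

The source may report more compounds than this note shows. Statements on the series, on what has been measured and on what is new or still open speak of the compounds shown alone.

Measured so far:
- compound 1 `Cc1cn([C@@H]2O[C@@H]3COC4(O)CS(=O)(=O)O[C@@]34[C@H]2O[Si](C)(C)C(C)(C)C)c(=O)[nH]c1=O` — 100000 nM
- compound 2 `Cc1cn([C@@H]2O[C@H](CO[Si](C)(C)C(C)(C)C)[C@@]3(OS(=O)(=O)C=C3NCCC(=O)O)[C@H]2O[Si](C)(C)C(C)(C)C)c(=O)n(C)c1=O` — 19400 nM

Both compounds were tested in a functional assay on CCRF-CEM cells (Homo sapiens) (on this read-out higher numbers stand for lower toxicity in this test and lower numbers for higher toxicity in this test), a test on a human leukemia cell line. Compound 1 gives 100000 nM, and compound 2 gives 19400 nM. Compound 2 therefore stands at the lowest of the two numbers, which means it is the more toxic of the two in this test; the gap to compound 1 is beyond the usual scatter of repeated measurements.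

Within the data shown here, the next compound, compound 3 `Cc1cn([C@@H]2O[C@H](CO[Si](C)(C)C(C)(C)C)[C@@]3(OS(=O)(=O)C=C3NCC(=O)OCc3ccccc3)[C@H]2O[Si](C)(C)C(C)(C)C)c(=O)n(C)c1=O`, keeps the core of compound 2 and changes only one group. The change is benzyloxycarbonyl in place of carboxymethyl on a saturated chain carbon bound to an amine nitrogen. Among the measured compounds shown here, no measured pair shows what such a change does here, so the expectation rests on compound 2 alone.

With only compound 2 as a reference, the step from compound 2 to compound 3 in this assay is expected to be small, a 1.6-fold lower number from compound 2 to compound 3 (0.21 log units; within the scatter), toward a slightly lower number. Compound 3 is therefore estimated at 12000 nM in this assay, within a range of 3000 nM to 50000 nM.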

Compound 3, half-maximal cytotoxic concentration: 250000 nM
Compound 3: middle estimate off by 21-fold (1.32 log units), on the low side; measured number outside the range, above it.
By their numbers in this assay, from the lowest: compound 2; then compound 1; then compound 3.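

In this assay, the result is a 13-fold higher number from compound 2 to compound 3 (1.11 log units; beyond the scatter), so the group carried on this saturated chain carbon bound to an amine nitrogen can move the number well beyond the scatter, here toward lower toxicity in this test. Compound 2 alone could not show that this position matters so much, nor which way such a change would go. The change is a bundle rather than a single edit: read one bond further out, it is 2-carboxyethyl to (benzyloxycarbonyl)methyl, so the acid gives way to an ester, the chain changes, hydrogen-bond donors go from 1 to 0, and a six-membered aromatic ring of carbon only enters, while no measurement offered here explains the shift.

Still open, going by these compounds, is which of these parts carries the step: the loss of the acid, the benzyl ring or the altered chain. A methyl ester on the same chain, or an amide in place of the ester, would help pull these parts apart.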